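From 2,6-dichlorophenyl to 4-fluorophenyl on the shared core

The source may hold more compounds than are shown below. What is called first, only, known or untested is meant among the compounds shown, and "the series" means these compounds.

Three chlorinated compounds sharing one core have been tested in a functional assay on cells (Tumor Cell line, Homo sapiens) for cytotoxicity; on this read-out higher numbers stand for weaker inhibition and lower numbers for stronger inhibition: compound 1 `CN(C)Cc1cc(C(=O)/C=C/c2cccc(Cl)c2)cc(CN(C)C)c1O` gives 4680 nM, compound 2 `CN(C)Cc1cc(C(=O)/C=C/c2ccc(Cl)cc2)cc(CN(C)C)c1O` gives 10000 nM and compound 3 `CN(C)Cc1cc(C(=O)/C=C/c2c(Cl)cccc2Cl)cc(CN(C)C)c1O` gives 5880 nM. Compound 3 cannot be separated from either of the others, with a 1.3-fold higher number from compound 1 to compound 3 (0.10 log units; within the scatter) and a 1.7-fold lower number from compound 2 to compound 3 (0.23 log units; within the scatter). Only a 2.1-fold higher number from compound 1 to compound 2 (0.33 log units; beyond the scatter) passes the scatter, and only modestly.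

Compound 4 `CN(C)Cc1cc(C(=O)/C=C/c2ccc(F)cc2)cc(CN(C)C)c1O` carries 4-fluorophenyl in place of 2,6-dichlorophenyl on a double-bonded chain carbon bound to a double-bonded chain carbon. Among the measured compounds shown here, no fluorinated compound has been measured, so the nearest guide is compound 2, which carries 4-chlorophenyl and gives 10000 nM. All three steps at this place are small, so a large move is not expected in this assay. The expected step, a 1.2-fold higher number from compound 3 to compound 4 (0.08 log units; within the scatter), is slightly upward and no larger than the scatter. For compound 4 the estimate is 7000 nM, with an expected range of 3500 nM to 14000 nM.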

Compound 4, half-maximal inhibitory concentration: 20000 nM
Compound 4: the middle estimate sits 2.9-fold (0.46 log units) below what was measured; measured number above the stated range.
By their numbers in this assay, from the lowest: compounds 1, 3, 2 and 4 (each within the scatter of the next, the first and the last beyond it).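

In this assay, among the compounds shown here, this position now gives clearer separations than the earlier compounds did, with 4-fluorophenyl set apart from both 2,6-dichlorophenyl (a 3.4-fold higher number from compound 3 to compound 4 (0.53 log units; beyond the scatter)) and 3-chlorophenyl (a 4.3-fold higher number from compound 1 to compound 4 (0.63 log units; beyond the scatter)), though both steps remain modest. The direct exchange of fluoro in place of chloro on an aromatic carbon (a 2.0-fold higher number from compound 2 to compound 4 (0.30 log units; within the scatter)) stays within the scatter, so compound 4 cannot be separated from compound 2. Nothing available here explains these differences.

For the compounds shown here, with only one fluorinated compound in view, it remains open whether 3-fluorophenyl would track 3-chlorophenyl or stand closer to 4-fluorophenyl. Going by these compounds, how an unsubstituted phenyl, 4-methoxyphenyl or 4-aminophenyl would compare on the shared core also remains open.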